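Hydrogen for methyl on an aromatic oxygen: cytotoxicity notes

The source may hold more compounds than are shown below. What is called first, only, known or untested is meant among the compounds shown, and "the series" means these compounds.

Compound 1 `COc1cc(C(=N)NC(C)C)cc2cc(-c3ccc(C(=N)NC(C)C)cc3)oc12` and compound 2 `CC(C)NC(=N)c1ccc(-c2cc3cc(C(=N)NC(C)C)cc(O)c3o2)cc1` differ only in hydrogen in place of methyl on an oxygen on an aromatic ring. In an ADME assay on L6 cells (Rattus norvegicus) for cytotoxicity (on this read-out higher numbers stand for weaker inhibition and lower numbers for stronger inhibition), compound 1 gives a limit, > 190000 nM. Compound 2 in this assay likewise gives a limit, > 185000 nM. The step that the two limits leave unreadable from compound 1 to compound 2 cannot be sized because the limit of > 185000 nM in this assay, at which 1 of the 3 values shown sits, and the limit of > 190000 nM in this assay, at which 1 of the 3 values shown sits, both cap the values. Compound 3 `COc1ccc(C(=N)N)cc1-c1cc2cc(C(=N)N)ccc2o1` carries a core whose difference from the core of compound 1 is not broken down here. In this assay, within the data shown here, compound 3 gives 179000 nM, the only number among the three measured compounds. Compound 4 `N=C(N)c1ccc(O)c(-c2cc3cc(C(=N)N)ccc3o2)c1`, not yet measured, differs from compound 3 by hydrogen in place of methyl on an oxygen on an aromatic ring, the same change as that from compound 1 to compound 2, at the same kind of place. Compound 4 is expected to move by a 1.0-fold higher number from compound 3 to compound 4 (0.00 log units; within the scatter), resting on compound 1 and compound 2 both sitting at the limits of this assay with a step that the two limits leave unreadable from compound 1 to compound 2 unreadable, so no large shift is indicated. Compound 4 is estimated at 180000 nM, between 90000 nM and 360000 nM, with a fair chance of only a limit.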

Compound 4, half-maximal inhibitory concentration: > 217000 nM
Compound 4 ended at the assay's limit (the forecaster's own chance of this, stated with the estimate: 40%); middle value at least 1.2-fold (0.08 log units) away from the limit.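

In this assay, from the compounds shown here alone, the change of hydrogen in place of methyl on the core of compound 3 gives an at least 1.2-fold higher number from compound 3 to compound 4 (0.08 log units; that floor lies within the scatter); this is only a floor, so the true size of the step remains open. Among these compounds, on the core of compound 1, the same change cannot be read, leaving no two sizes to compare between the cores and no evidence that the step carries over in size. What the two cores do share is narrow: the hydroxy member of each pair, compound 2 and compound 4 alike, ends at a limit of this assay.

Open, going by these compounds, is how other groups on the same oxygen on an aromatic ring, such as ethoxy or a longer chain, would read on either core. Also open, on these data alone, is whether an amine or a carboxylic acid in place of the methoxy group would give a readable number in this assay.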